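This account rests on a few compounds, and the source may have more. Where it says the series, first, only, none or still open, it means among the compounds named here.

In a functional assay on HOS-TE85 cells (Homo sapiens) for inhibition, read by CCK-8 assay, with a stated time of 72 h (on this read-out higher numbers stand for weaker inhibition and lower numbers for stronger inhibition), compound 1 `COc1ccc(C)cc1N1C(=O)CSC1c1cccc(C(=O)NCCCCc2ccccc2)c1` gives 300 nM.
Compound 2 `COc1ccc(OC)c(N2C(=O)CSC2c2cccc(C(=O)NCCCCc3ccccc3)c2)c1` reaches only the limit of the assay, > 1000 nM.

Of the two numbers shown, compound 2 stands at the weaker end, and for it only a limit is known, (the limit of > 1000 nM in this assay, at which 1 of the 2 values shown sits). Within the data shown here, the single measured step, an at least 3.3-fold higher number from compound 1 to compound 2 (0.52 log units; beyond the scatter), shows that a small change on the aromatic ring attached to the ring nitrogen can move the number well beyond the usual scatter.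

Compound 3 `CC(C)(C)c1conc1N1C(=O)CSC1c1cccc(C(=O)NCCCCc2ccccc2)c1` differs from compound 2 by a group of 9 heavy atoms (7 carbon, 1 nitrogen, 1 oxygen; one five-membered aromatic ring with 2 hetero atoms) in place of a group of 10 heavy atoms (8 carbon, 2 oxygen; one six-membered aromatic ring of carbon only), on an amide-type nitrogen in a ring. Among the measured compounds shown here, no measured step covers such an exchange of one aromatic ring for another; the one measured step only shows the sensitivity of this position. The direction is therefore open, with a limit again a real possibility.

In this assay compound 3 is expected to give about 800 nM, within 200 nM to 3000 nM. The expected step is an at least 1.2-fold lower number from compound 2 to compound 3 (0.09 log units; that floor lies within the scatter).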

Compound 3, half-maximal inhibitory concentration: > 1000 nM
Compound 3: only a limit was reported; the forecaster's own chance of this, stated with the estimate: 45%; middle value at least 1.2-fold (0.09 log units) away from the limit.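

Placing a five-membered aromatic ring with 2 hetero atoms on the amide-type nitrogen, in place of the six-membered aromatic ring of compound 1, gives an at least 3.3-fold higher number from compound 1 to compound 3 (0.52 log units; beyond the scatter). This position therefore responds to an exchange of the whole aromatic ring, and not only to a small change on it. In this assay compound 3 gives > 1000 nM, which is a limit and not a number, so the step between compound 2 and compound 3 cannot be read, and neither can their order: the limit of > 1000 nM in this assay, at which 2 of the 3 values shown sit.

From the compounds shown here alone, it remains open whether a plain phenyl ring or a pyridine ring on this nitrogen would give a number lower than that of compound 1. The compounds shown also leave open how far either ring change would carry over to a shorter chain on the amide.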